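A few compounds are considered here, and "the series" means these few. Any claim that something is new, unique, unknown or untested is made for them only; others in the source may bear on it.

In a functional assay on DLD-1 cells (Homo sapiens) for inhibition, read by luminescence, with a stated time of 3 days (on this read-out lower numbers stand for stronger inhibition of growth and higher numbers for weaker inhibition of growth), compound 1 (`CC[C@@H]1CC[C@@H](C(=O)N2CCN(C(C)=O)CC2)N1C(=O)C1=C(C(C)C)N2C(=N[C@@](C)(c3ccc(Cl)cc3)[C@H]2c2ccc(Cl)cc2)S1`) gives 9300 nM and compound 2 (`CC(=O)N1CCN(C(=O)[C@@H]2CC[C@@H](C)N2C(=O)C2=C(C(C)C)N3C(=N[C@@](C)(c4ccc(Cl)cc4)[C@H]3c3ccc(Cl)cc3)S2)C[C@H]1C`) gives 11000 nM. Among the compounds with values here, these two numbers lie within the usual scatter of each other, so compound 1 stands level with the only other measured compound. Compound 3 (`CC[C@@H]1CC[C@@H](C(=O)N2CCN(C(C)=O)[C@@H](C)C2)N1C(=O)C1=C(C(C)C)N2C(=N[C@@](C)(c3ccc(Cl)cc3)[C@H]2c2ccc(Cl)cc2)S1`) differs from compound 1 by methyl in place of hydrogen on a saturated ring carbon. Within the data shown here, no measured step isolates this change. With compound 1 at 9300 nM as the starting point, no step beyond the scatter is expected in this assay. For compound 3 the estimated value is 10000 nM, with an expected range of 4500 nM to 22000 nM.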

Compound 3, concentration for 50% growth inhibition: 2600 nM
Beside the measured number, compound 3's estimate is 3.8-fold (0.59 log units) above it; the whole stated range lies above it.
By their numbers in this assay, from the lowest: compound 3; then compounds 1 and 2 (each within the scatter of the next).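

In this assay, methyl in place of hydrogen on a saturated ring carbon of the six-membered non-aromatic ring with 2 nitrogen gives a 3.6-fold lower number from compound 1 to compound 3 (0.55 log units; beyond the scatter). This shows that the number responds to a change at this position, and that one added carbon is enough to carry the step beyond the scatter. No measurement shown here offers an explanation for this step. As far as these compounds go, whether an ethyl group, a hydroxyl group or an amine on this carbon would give a similar step stays open, as does the effect of the methyl in the opposite stereochemistry.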